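Removing a trifluoromethyl group on an anilinoquinazoline series

A few compounds are considered here, and "the series" means these few. Any claim that something is new, unique, unknown or untested is made for them only; others in the source may bear on it.

Measured compounds:
Compound 1, `c1ccc(COc2ccccc2Nc2ncnc3cc4c(cc23)OCCOCCOCCO4)cc1`: 63300 nM
Compound 2, `FC(F)(F)c1ccc(COc2ccccc2Nc2ncnc3cc4c(cc23)OCCOCCOCCO4)cc1`: > 100000 nM
Compound 3, `FC(F)(F)c1ccc(COc2cccc(Nc3ncnc4cc5c(cc34)OCCOCCOCCO5)c2)cc1`: 17600 nM

All three were tested in a functional assay on MCF7 cells (Homo sapiens) for antiproliferative activity, read by MTT assay, with a stated time of 72 h; on this read-out lower numbers stand for stronger inhibition and higher numbers for weaker inhibition. Compound 2 reached only a limit of this assay, > 100000 nM, and not a number (the limit of > 100000 nM in this assay, at which 1 of the 3 values shown sits). Compound 1 and compound 2 differ in one place, (hydrogen in place of trifluoromethyl on an aromatic carbon), and this change gave an at least 1.5-fold lower number from compound 2 to compound 1 (0.19 log units; that floor lies within the scatter).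

Compound 3 has the lowest number of the two measured numbers, with compound 1 the nearest, at a gap beyond the usual scatter. How compound 3 differs from compound 2 is not broken down here, as the two have the same atoms joined differently.

Compound 4, `c1ccc(COc2cccc(Nc3ncnc4cc5c(cc34)OCCOCCOCCO5)c2)cc1`, has not yet been measured. It is made from compound 3 by the same change, (hydrogen in place of trifluoromethyl on an aromatic carbon), that leads from compound 2 to compound 1. Because that earlier change gave an at least 1.5-fold lower number from compound 2 to compound 1 (0.19 log units; that floor lies within the scatter), a step of similar or slightly larger size is expected here, though the earlier step only sets a floor. Compound 4 is therefore expected to show a step of a 1.8-fold lower number from compound 3 to compound 4 (0.25 log units; within the scatter), giving an estimated 10000 nM, with a range from 4000 nM to 35000 nM.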

Compound 4, half-maximal inhibitory concentration: > 100000 nM
Compound 4: a limit, no number; the forecaster's own chance of this, stated with the estimate: 5%; middle value at least 10-fold (1.00 log units) away from the limit.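

In this assay compound 4 reached only a limit, > 100000 nM, and not a number. Replacing trifluoromethyl with hydrogen on this core gave an at least 5.6-fold higher number from compound 3 to compound 4 (0.75 log units; beyond the scatter), so the result from the first pair did not carry over to the second: the same change on two cores in this assay, an at least 1.5-fold lower number (0.19 log units; that floor lies within the scatter) from compound 2 to compound 1 and an at least 5.6-fold higher number (0.75 log units; beyond the scatter) from compound 3 to compound 4, at least 8.9-fold (0.95 log units) apart, beyond the scatter of two such steps. This shows that, in this series, the effect of the change depends on the core that carries it, but each step rests on a limit, so neither its true size nor the true gap between the two steps is known, and two pairs reveal neither the reason for the difference nor a rule for other cores: the limit of > 100000 nM in this assay, at which 2 of the 4 values shown sit.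

On these data alone, it remains open whether a group other than trifluoromethyl on the same aromatic carbon, such as a chlorine, a methyl or a methoxy, would give a measurable number on both cores. As far as these compounds go, the response to a more different group there, such as a nitrile or an amine, also remains unknown.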